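Removing the ring-nitrogen methyl from a methoxypyridine analogue

The compounds below may be only part of what the source reports. "The series", "measured", "known", "first", "only" and "open" are said of these compounds alone.

Three compounds built on a shared bicyclic amine core carrying a pyridine have been measured in an in vitro assay on SH-SY5Y cells for displacement of a labelled ligand from Neuronal acetylcholine receptor; alpha3/beta4 (Homo sapiens); on this read-out higher numbers stand for weaker inhibition and lower numbers for stronger inhibition. Compound 1 `C1=C(c2cccnc2)CC2CNCC1C2`, which has no substituent on the pyridine and a bare ring amine, gives 12 nM. Compound 2 `CC(C)Oc1cncc(C2=CC3CC(C2)CN(C)C3)c1`, with an isopropoxy group on the pyridine and a methyl on the ring amine, gives 1730 nM. Compound 3 `COc1cncc(C2=CC3CC(C2)CN(C)C3)c1` is the methoxy counterpart of compound 2; in this assay compound 3 gives 596 nM. For the measured compounds named here, on these numbers compound 3 stands second highest of the three: its nearest neighbour is compound 2, and the only single-point step recorded, a 2.9-fold lower number from compound 2 to compound 3 (0.46 log units; beyond the scatter), concerns the alkoxy group rather than the amine. Going by the values given here, compound 1 lies far below it, but compound 1 and compound 3 differ in two places, so their values show only that the pair of changes together carries a large gap.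

Compound 4 `COc1cncc(C2=CC3CNCC(C2)C3)c1` differs from compound 3 by hydrogen in place of methyl on an amine nitrogen in a ring. Among the compounds with values here, no measured step isolates this change, so the direction must be inferred from the fact that compound 1, the only other bare-amine compound, gives 12 nM. Compound 4 is therefore expected to give a lower number than compound 3, with a step of a 6.0-fold lower number from compound 3 to compound 4 (0.78 log units; beyond the scatter). The estimate for compound 4 in this assay is 100 nM, within a range of 25 nM to 400 nM.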

Compound 4, inhibition constant: 14.3 nM
Estimate against measurement, compound 4: 7.0-fold (0.84 log units) above, outside the stated range (below it).
By their numbers in this assay, from the lowest: compounds 1 and 4 (each within the scatter of the next); then compound 3; then compound 2.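

For the compounds shown here, on the shared core carrying a methoxy group, the amine nitrogen in the ring proves to be a highly sensitive place in this assay: hydrogen in place of methyl there gives a 42-fold lower number from compound 3 to compound 4 (1.62 log units; beyond the scatter), far more than the only earlier single-place step, which concerned the alkoxy group and amounted to a 2.9-fold lower number from compound 2 to compound 3 (0.46 log units; beyond the scatter). With a bare ring amine, methoxy in place of hydrogen on an aromatic carbon gives a 1.2-fold higher number from compound 1 to compound 4 (0.08 log units; within the scatter), so of the two changes separating compound 1 from compound 3, the methyl on the ring nitrogen accounts for the large difference in these values, while the methoxy group leaves no difference beyond the scatter when the amine is bare. The compounds shown offer no independent information on why this single methyl carries such a large step.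

Going by these compounds, it remains open whether hydrogen in place of methyl would give a step of similar size with the isopropoxy group of compound 2 in place of methoxy. The compounds shown also leave open how a longer chain such as ethyl on the ring nitrogen, or a group such as an amine on the aromatic ring, would read in this assay.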